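The compounds below may be only part of what the source reports. "The series", "measured", "known", "first", "only" and "open" are said of these compounds alone.

Compounds measured in an assay on cells (Oocyte) for negative allosteric modulation of glutamate receptor ionotropic, NMDA 2D (Rattus norvegicus), read by two-electrode voltage clamp; on this read-out higher numbers stand for weaker inhibition and lower numbers for stronger inhibition:
compound 1, `Cc1ccc(-c2c(C3=NN(C(=O)CCC(=O)O)C(c4ccc(Cl)cc4)C3)c(=O)[nH]c3ccccc23)cc1`, 1400 nM
compound 2, `COc1ccc(-c2c(C3=NN(C(=O)CCC(=O)O)C(c4ccc(Cl)cc4)C3)c(=O)[nH]c3ccccc23)cc1`, 2300 nM
compound 3, `Cc1cccc(-c2c(C3=NN(C(=O)CCC(=O)O)C(c4ccc(Cl)cc4)C3)c(=O)[nH]c3ccccc23)c1`, 1900 nM

Compound 1 and compound 2 differ by one change, (methoxy in place of methyl on an aromatic carbon), and the step it made is a 1.6-fold higher number from compound 1 to compound 2 (0.22 log units; within the scatter). Compound 3 stands apart from compound 1 through a rearrangement of the same atoms, (3-methylphenyl in place of 4-methylphenyl on an aromatic carbon), giving a 1.4-fold higher number from compound 1 to compound 3 (0.13 log units; within the scatter). Between compound 2 and compound 3 the step is a 1.2-fold lower number from compound 2 to compound 3 (0.08 log units; within the scatter), so all three compounds sit within the scatter of one another.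

Compound 4, `COc1cccc(-c2c(C3=NN(C(=O)CCC(=O)O)C(c4ccc(Cl)cc4)C3)c(=O)[nH]c3ccccc23)c1`, has not yet been measured. It is reached from compound 3 by methoxy in place of methyl on an aromatic carbon. This is the same kind of change as that from compound 1 to compound 2, but not the same: in the earlier pair the group sat para to a large group, whereas here it sits meta to a large group. If the change behaves as it did from compound 1 to compound 2, the step from compound 3 to compound 4 in this assay is expected to be a 1.5-fold higher number from compound 3 to compound 4 (0.17 log units; within the scatter), resting on compound 1 at 1400 nM and compound 2 at 2300 nM. Compound 4 is thus estimated at 2800 nM, with a plausible range from 1300 nM to 6000 nM.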

Compound 4, half-maximal inhibitory concentration: 4500 nM
Compound 4: the middle estimate sits 1.6-fold (0.21 log units) below what was measured; low and high end bracket the measured number.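

In this assay, methoxy in place of methyl, here on an aromatic carbon meta to a large group, gives a 2.4-fold higher number from compound 3 to compound 4 (0.37 log units; beyond the scatter). Set beside the earlier case, this step does not differ from it by more than two such steps can scatter, so the change carried from one core to the other without a distinguishable difference: the same change on two cores in this assay, a 1.6-fold higher number (0.22 log units; within the scatter) from compound 1 to compound 2 and a 2.4-fold higher number (0.37 log units; beyond the scatter) from compound 3 to compound 4, 1.4-fold (0.16 log units) apart, within the scatter of two such steps. The remaining steps are a 2.0-fold higher number from compound 2 to compound 4 (0.29 log units; within the scatter) and a 3.2-fold higher number from compound 1 to compound 4 (0.51 log units; beyond the scatter), but two pairs do not establish a rule for the series, and they do not show why one step lies within the scatter and the other beyond it.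

The compounds shown leave open how the same aromatic carbon would respond to groups other than methyl and methoxy, such as a fluorine, a hydroxyl or an ethoxy. They also leave open whether the step from methyl to methoxy would hold with a longer chain in place of the one carrying the carboxylic acid.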